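This account rests on a few compounds, and the source may have more. Where it says the series, first, only, none or still open, it means among the compounds named here.

Measured so far:
Compound 1, `O=C(C1CC1)N1CCc2nc(C#Cc3ccccc3)sc2C1`: > 10000 nM (a limit, not a number)
Compound 2, `O=C(C1CCCCO1)N1CCc2nc(C#Cc3ccccc3)sc2C1`: 320 nM

In an assay on HEK293 cells for positive allosteric modulation of metabotropic glutamate receptor 5 (Homo sapiens), read by FLIPR, with a stated time of 1 h (a lower number here means that less compound is needed, a higher number that more compound is needed for the effect), compound 1 returns > 10000 nM, which is a limit of the assay rather than a measured number; this is the limit of > 10000 nM in this assay, at which 1 of the 2 values shown sits. Within the data shown here, compound 2, which differs only in carrying oxan-2-yl rather than cyclopropyl on the carbonyl carbon, gives 320 nM in this assay, and so holds the only actual number among the two values shown. Among the measured compounds shown here, the one measured step, an at least 31-fold lower number from compound 1 to compound 2 (1.49 log units; beyond the scatter), shows that the group on the carbonyl carbon matters a great deal for this read-out.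

Compound 3, `N#Cc1cccc(C(=O)N2CCc3nc(C#Cc4ccccc4)sc3C2)c1`, has not yet been measured. Its change from compound 2 is 3-cyanophenyl in place of oxan-2-yl on a carbonyl carbon. For the measured compounds named here, no measured step covers a swap from a saturated ring to an aromatic one at this position, so the single measured step only indicates that changes here can be large, not in which direction this one goes. On that basis compound 3 is estimated at 300 nM, with a range of 60 nM to 1500 nM, meaning an expected step of a 1.1-fold lower number from compound 2 to compound 3 (0.03 log units; within the scatter).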

Compound 3, half-maximal effective concentration: 71 nM
Estimate against measurement, compound 3: 4.2-fold (0.63 log units) above; low and high end bracket the measured number.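

In this assay, among these compounds, the earlier compounds showed only that a non-aromatic ring carrying an oxygen could far outdo cyclopropyl on the carbonyl carbon, but 3-cyanophenyl, a six-membered aromatic ring of carbon only with a nitrile attached, goes further, with a 4.5-fold lower number from compound 2 to compound 3 (0.65 log units; beyond the scatter). The place therefore accepts an aromatic ring, and the ring oxygen of oxan-2-yl is not needed for a low number, while the comparison with cyclopropyl gives an at least 140-fold lower number from compound 1 to compound 3 (2.14 log units; beyond the scatter). Compound 1 stands at a limit and not at a number, so this largest step has only one fixed end: the limit of > 10000 nM in this assay, at which 1 of the 3 values shown sits.

Because the swap replaces the ring and adds the nitrile in one move, the compounds shown cannot say how much of the gain belongs to the aromatic ring and how much to the nitrile; a plain phenyl on the same carbonyl carbon would separate the two. Also open, going by these compounds, is whether other groups on that ring, such as a chlorine or a methoxy group, or a pyridyl ring in its place, would serve as well.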